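From Trifluoromethyl to Methylsulfanyl on a Shared Core

The source may hold more compounds than are shown below. What is called first, only, known or untested is meant among the compounds shown, and "the series" means these compounds.

Compound 1 `CC1(C)OC(/C=C/c2ccc(Cl)cc2Cl)=CC1=O`: 20%
Compound 2 `CC1(C)OC(/C=C/c2ccc(S(C)(=O)=O)cc2)=CC1=O`: 56%
Compound 3 `CC1(C)OC(/C=C/c2ccc(C(F)(F)F)cc2)=CC1=O`: 30%

All three compounds share one core and differ only in the group on the aromatic ring. In a functional assay on the whole organism for inhibition, with Rattus norvegicus as the target, with a stated time of 1 h, at a dose of 25 mg/kg by the oral route (a lower number here means less inhibition, a higher number more inhibition at the dose given (going by the name of the read-out)), compound 2 gives 56%, compound 3 gives 30% and compound 1 gives 20%. Compound 3 therefore stands second of the three. Compound 1 and compound 3 lie within the usual scatter of each other, so no order can be read between them. Going by the values given here, the only clear step is a number 26 percentage points lower from compound 2 to compound 3 (beyond the scatter), a modest fall beyond the scatter.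

Compound 4 `CSc1ccc(/C=C/C2=CC(=O)C(C)(C)O2)cc1` is not yet measured. Its difference from compound 3 is methylsulfanyl in place of trifluoromethyl on an aromatic carbon. Among the compounds with values here, no measured step involves methylsulfanyl, so the expectation rests on indirect ground. Methylsulfanyl shares with methylsulfonyl one counted hydrogen-bond acceptor, and compound 2 with methylsulfonyl gave the highest number, so a rise from compound 3 is expected, but a small one, and possibly none beyond the scatter. The expected step is a number 10 percentage points higher from compound 3 to compound 4 (within the scatter). Compound 4 is estimated to give 40%, with a range from 15% to 65%.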

Compound 4, a percentage reported as inhibition, in the whole organism at one dose (the size of the read-out at that dose, not a potency): 5%
The estimate for compound 4 lay 35 percentage points above the measured number; the measured number lies below the stated range.
By their numbers in this assay, from the lowest: compound 4; then compounds 1 and 3 (each within the scatter of the next); then compound 2.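

In this assay, methylsulfanyl in place of trifluoromethyl gives a number 25 percentage points lower from compound 3 to compound 4 (beyond the scatter), so this change on the aromatic carbon moves the read-out down, not up, even though methylsulfanyl brings a counted hydrogen-bond acceptor that trifluoromethyl lacks. The sharper lesson comes from the pair that both carry sulfur: methylsulfanyl in place of methylsulfonyl gives a number 51 percentage points lower from compound 2 to compound 4 (beyond the scatter), the biggest step seen so far, which shows that having a sulfur-bearing group at this position is not enough to keep the high number of compound 2 . Nothing available here measures a property of these groups or of the compounds that could account for either fall.

The compounds shown leave open whether the high number of compound 2 belongs to the methylsulfonyl group alone or would also appear with another group at this position, such as methylsulfinyl, a sulfonamide, a nitrile or a carboxylic acid. With only one dose and one time point, they also leave open whether the gap between these compounds would hold at other doses or at other times.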